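Fluoro in Place of Methoxy on the Benzyl Group

A few compounds are considered here, and "the series" means these few. Any claim that something is new, unique, unknown or untested is made for them only; others in the source may bear on it.

Compound 1 `CCOC(=O)C1(Cc2ccccc2)CN(c2ccccc2)Cc2nnn(Cc3ccccc3)c21` gives >= 20000 nM in an ADME assay on HEL cells (Homo sapiens) for cytotoxicity, read by microscopy, with a stated time of 3 days (on this read-out higher numbers stand for lower toxicity in this test and lower numbers for higher toxicity in this test), which is a limit of the assay.
Compound 2 `CCOC(=O)C1(Cc2ccccc2)CN(c2ccccc2)Cc2nnn(Cc3cc(OC)c(OC)c(OC)c3)c21` gives >= 100000 nM in this assay, again a limit.
Compound 3 `CCOC(=O)C1(Cc2ccccc2)CN(c2ccccc2)Cc2nnn(Cc3ccc(OC)cc3)c21` gives > 100000 nM in this assay, also a limit.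

Compound 3 therefore stands at a limit, not at a number, and the two other values shown are limits as well (the limit of > 100000 nM in this assay, at which 1 of the 3 values shown sits, (the limit of >= 100000 nM in this assay, at which 1 of the 3 values shown sits), (the limit of >= 20000 nM in this assay, at which 1 of the 3 values shown sits)). Going by the values given here, none of the measured steps can be read: a step that the two limits leave unreadable from compound 1 to compound 3, a step that the two limits leave unreadable from compound 1 to compound 2 and a step that the two limits leave unreadable from compound 2 to compound 3 all stay hidden behind the limits.

Compound 4 `CCOC(=O)C1(Cc2ccccc2)CN(c2ccccc2)Cc2nnn(Cc3ccc(F)cc3)c21` differs from compound 3 in one place: fluoro in place of methoxy on an aromatic carbon. Among the compounds with values here, no measured step touches the fluoro group, and the steps that touch the methoxy group are unreadable, so nothing here points to a change in either direction beyond the usual scatter. The expectation for compound 4 is that this assay again reaches only a limit, with the toxicity read-out estimated at 100000 nM, within a range of 30000 nM to 200000 nM. The step that this estimate means, a number no higher from compound 3 to compound 4 (the limit leaves the size open), is expected to be no more than the scatter.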

Compound 4, minimum cytotoxic concentration: >= 100000 nM
Compound 4 ended at the assay's limit; the forecaster's own chance of this, stated with the estimate: 80%; the middle value lies on the limit itself.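

Compound 4 also ended at a limit in this assay, as did compound 1, compound 2 and compound 3, and none of the steps from these three to compound 4 can be read. The compounds shown leave open whether fluoro, methoxy or hydrogen on the benzyl group changes the toxicity read-out at all.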